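Configurational steps on a shared polyhydroxylated core

The source may hold more compounds than are shown below. What is called first, only, known or untested is meant among the compounds shown, and "the series" means these compounds.

Three stereoisomers of one core have been run in an assay on isolated protein for inhibition of cytosolic endo-beta-N-acetylglucosaminidase (Homo sapiens), tested at 1000 uM; on this read-out higher numbers stand for more inhibition at the one concentration tested (going by the name of the read-out) and lower numbers for less inhibition. Compound 1 `O=C(O)[C@H]1NC[C@H](O)[C@H](O)[C@H]1O` gives 7.6%. Compound 2 `O=C(O)[C@H]1NC[C@H](O)[C@@H](O)[C@H]1O` gives 2.6%. For the measured compounds named here, compound 3 `O=C(O)[C@@H]1NC[C@@H](O)[C@H](O)[C@@H]1O` gives 0.8% and sits at the lower end of the three numbers, although no pair is separated by more than the scatter. The measured steps confirm this: a number 5 percentage points lower from compound 1 to compound 2 (within the scatter), a number 6.8 percentage points lower from compound 1 to compound 3 (within the scatter) and a number 1.8 percentage points lower from compound 2 to compound 3 (within the scatter) all lie within the scatter, and each rests on a change of configuration alone the fact that compounds 1 and 2 differ only in the configuration as drawn the fact that compounds 1 and 3 differ only in the configuration as drawn (the fact that compounds 2 and 3 differ only in the configuration as drawn).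

Compound 4 `O=C(O)[C@H]1NC[C@@H](O)[C@H](O)[C@@H]1O` is the next isomer. Relative to compound 3 the change is the two compounds have the same atoms and bonds and differ only in configuration as drawn: 1 of 4 stereo elements differ; a stereocentre at a saturated ring carbon is drawn R in compound 3 and S in compound 4. Going by the values given here, the closest precedent is the single-centre inversion between compound 1 and compound 2, which gave a number 5 percentage points lower from compound 1 to compound 2 (within the scatter); the larger inversions, three centres and the full mirror image, likewise moved nothing beyond the scatter. Among the compounds with values here, no measured step therefore supports a shift of any size in this assay, in either direction, for a single configurational change on this core.

The step from compound 3 to compound 4 is expected to be a number 2.7 percentage points higher from compound 3 to compound 4 (within the scatter). Compound 4 is accordingly estimated at 3.5%, with a range from 0% to 11%.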

Compound 4, a percentage reported as inhibition, at one concentration (the size of the read-out at that concentration, not a potency): 42%
The estimate for compound 4 lay 38.5 percentage points below the measured number; measured number above the stated range.
By their numbers in this assay, from the lowest: compounds 3, 2 and 1 (each within the scatter of the next); then compound 4.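

In this assay, configuration on the shared core is not silent, as the earlier isomers had left it looking: inverting one stereocentre at a saturated ring carbon gives a number 41.2 percentage points higher from compound 3 to compound 4 (beyond the scatter). The steps with more stereo elements differing are also large, a number 39.4 percentage points higher from compound 2 to compound 4 (beyond the scatter) with three differing and a number 34.4 percentage points higher from compound 1 to compound 4 (beyond the scatter) with two, which sets this isomer apart from the other three, whose numbers all lie within the scatter of one another. The gain can be placed on the drawn configuration alone, since no atom or bond changes: the fact that compounds 3 and 4 differ only in the configuration as drawn

From the compounds shown here alone, the read-out at one concentration gives no potency for compound 4, so how much inhibition it retains at lower concentrations stays open. Going by these compounds, all four compounds carry the carboxylic acid and an unsubstituted ring amine, and it remains open whether the number for compound 4 holds with a methyl ester or a primary amide in place of the acid, or with a longer chain such as n-butyl on the ring nitrogen.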